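Aryl swap at the imine carbon of compound 1

The compounds below may be only part of what the source reports. "The series", "measured", "known", "first", "only" and "open" are said of these compounds alone.

Compound 1 `CC(C)(C)CC[C@H](c1ccc(C(=O)NCc2nn[nH]n2)cc1)N1C(=O)C(c2cncc(Cl)c2)=N[C@]12CC[C@@H](C(C)(C)C)CC2` is the reference point in this set. In an assay on CHO cells for displacement of a labelled ligand from Glucagon receptor (Homo sapiens), read by scintillation counting, with a stated time of 60 min (on this read-out lower numbers stand for stronger inhibition and higher numbers for weaker inhibition), compound 1 gives 38 nM, the lowest number of the three measured; compound 3 `C[C@H](c1ccc(C(=O)NCCC(=O)O)cc1)N1C(=O)C(c2cccc(Cl)c2F)=N[C@]12CC[C@@H](C(C)(C)C)CC2` gives 620 nM and compound 2 `CC(C)(C)[C@H]1CC[C@]2(CC1)N=C(c1cccc(Cl)c1)C(=O)N2Cc1ccc(C(=O)NCCC(=O)O)cc1` gives 770 nM, both beyond the scatter above compound 1, so compound 1 stands clearly as the most potent of the three. Going by the values given here, compounds 2 and 3 differ from compound 1 in several places at once, so no single step between measured compounds is available to lean on.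

Compound 4 `CC(C)(C)CC[C@H](c1ccc(C(=O)NCc2nn[nH]n2)cc1)N1C(=O)C(c2cnccc2C(F)(F)F)=N[C@]12CC[C@@H](C(C)(C)C)CC2` changes one thing against compound 1: 4-(trifluoromethyl)pyridin-3-yl in place of 5-chloropyridin-3-yl on a carbon with a double bond to nitrogen. The new group is larger by three heavy atoms and keeps the one hydrogen-bond acceptor of the ring. Nothing measured speaks to this exchange directly. The expectation is a small step, no larger than the scatter or a little beyond it, in the direction of a weaker number, the step from compound 1 to compound 4 being estimated as a 1.7-fold higher number from compound 1 to compound 4 (0.23 log units; within the scatter). Compound 4 is expected to give about 65 nM in this assay, within a range from 20 nM to 220 nM.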

Compound 4, half-maximal inhibitory concentration: 22 nM
Compound 4: the middle estimate sits 3.0-fold (0.47 log units) above what was measured; low and high end bracket the measured number.
By their numbers in this assay, from the lowest: compounds 4 and 1 (each within the scatter of the next); then compounds 3 and 2 (each within the scatter of the next).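

The exchange of 5-chloropyridin-3-yl for 4-(trifluoromethyl)pyridin-3-yl in this assay gives a 1.7-fold lower number from compound 1 to compound 4 (0.24 log units; within the scatter), so the two groups cannot be told apart on this read-out. On the core of compound 1, this carbon with a double bond to nitrogen therefore accepts a group of 10 heavy atoms in place of one of 7, with a different substituent on the pyridine ring, without a step beyond the scatter. No measurement at hand explains why the two groups read alike.

Open, going by these compounds, is what a pyridin-3-yl carrying a nitrile or an amine in place of trifluoromethyl would give on this core. Also open, on these data alone, is whether a single step at this position can go beyond the scatter, as one exchange offers no such reading.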